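The source may report more compounds than this note shows. Statements on the series, on what has been measured and on what is new or still open speak of the compounds shown alone.

Notes on the series. In a functional assay on MDA-MB-231 cells (Homo sapiens) for inhibition, read by MTT assay and WST assay, with a stated time of 72 h, tested at 10 uM (on this read-out higher numbers stand for more inhibition of growth at the one concentration tested and lower numbers for less inhibition of growth), compound 1 `O=C(Nc1ccc(Cl)cc1)Nc1ccc(Oc2ccc(-c3nccs3)cc2)cc1` gives 32.5%. Compound 2 `CC(=O)Oc1sccc1NC(=O)Nc1ccc(Oc2ccc(-c3nccs3)cc2)cc1` gives 11% in this assay, and the step of a number 21.5 percentage points lower from compound 1 to compound 2 (beyond the scatter). Compound 3 `O=C(Nc1ccc(Cl)cc1)Nc1ccc(Oc2ccc(-c3ncc[nH]3)cc2)cc1` gives 47.6% in this assay, and the step of a number 15.1 percentage points higher from compound 1 to compound 3 (beyond the scatter). Within the data shown here, compound 3 therefore stands highest of the three numbers measured so far, with compound 1 nearest to it and compound 2 furthest away.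

Compound 4 `O=C(Nc1ccc(Oc2ccc(-c3ncc[nH]3)cc2)cc1)Nc1ccc(Cl)c([N+](=O)[O-])c1` differs from compound 3 by nitro in place of hydrogen on an aromatic carbon. Neither measured step bears directly on this change: the step from compound 1 to compound 2 exchanges the whole 4-chlorophenyl on the amide-type nitrogen, and the step from compound 1 to compound 3 exchanges the 1,3-thiazol-2-yl for 1H-imidazol-2-yl. Both of those steps were modest in size, which indicates that single-group changes in this series shift the read-out by modest amounts at most. With no direction indicated by any measured pair, the expected step of a number 2.4 percentage points higher from compound 3 to compound 4 (within the scatter) is small. Compound 4 is accordingly estimated to give 50% in this assay, within a range from 30% to 70%.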

Compound 4, percent growth inhibition at one concentration: 3.36%
Compound 4: middle estimate off by 46.6 percentage points, on the high side; measured number below the stated range.
By their numbers in this assay, from the lowest: compounds 4 and 2 (each within the scatter of the next); then compound 1; then compound 3.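

Nitro in place of hydrogen on the 4-chlorophenyl, ortho to the chloro group and meta to a large group, produces the only large step in the series, a number 44.2 percentage points lower from compound 3 to compound 4 (beyond the scatter) in this assay, whereas the earlier single-place changes were modest. This position is therefore far from indifferent to substitution, and keeping the 1H-imidazol-2-yl of compound 3 does not preserve the read-out once the nitro enters. No measurement here bears on the reason for this step.

From the compounds shown here alone, whether the loss is specific to nitro remains open, since an amine or a methoxy group at the same position could separate that group from substitution there in general. Going by these compounds, it is also open whether the same nitro change would act alike with the 1,3-thiazol-2-yl of compound 1.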